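Working notes: ring swap on the fluoro-bearing aryl of compound 3

A few compounds are considered here, and "the series" means these few. Any claim that something is new, unique, unknown or untested is made for them only; others in the source may bear on it.

Measured so far in an in vivo ADME assay on the whole organism (strain Sprague-Dawley) for pharmacokinetics, with Rattus norvegicus as the target, at a dose of 10 mg/kg by the oral route; on this read-out higher numbers stand for higher oral bioavailability and lower numbers for lower oral bioavailability:
- compound 1 `Cc1nc(-c2c(F)cccc2-c2ccc([C@@H](C)Nc3nccc(Cl)c3NC(=O)CC#N)cc2)no1` gives 50%
- compound 2 `COC(=O)c1ccc(Cl)cc1-c1ccc([C@@H](C)Nc2nccc(Cl)c2NC(=O)CC#N)cc1` gives 6%
- compound 3 `Cc1noc(-c2c(F)cccc2-c2ccc([C@@H](C)Nc3nccc(Cl)c3NC(=O)CC#N)cc2)n1` gives 62%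

Compound 3 holds the highest number of the three. The nearest is compound 1, whose value is lower by a step beyond the scatter, and the furthest is compound 2, whose value is lower by a much larger margin, also beyond the scatter.

Compound 4 `C[C@@H](Nc1nccc(Cl)c1NC(=O)CC#N)c1ccc(-c2cccc(F)c2-c2nnn(C)n2)cc1` is the next candidate. The change from compound 3 is 2-methyl-2H-tetrazol-5-yl in place of 3-methyl-1,2,4-oxadiazol-5-yl on an aromatic carbon. Among the compounds with values here, the only measured step that touches this position is a number 12 percentage points higher from compound 1 to compound 3 (beyond the scatter), which rearranged the same five-membered ring with three hetero atoms and gave a modest gain. Within the data shown here, no measured pair swaps in a 2-methyl-2H-tetrazol-5-yl, and compound 2, the low outlier, differs at more than one place, so its value shows only that large losses are possible.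

Given that the one relevant step was modest, the expected step of a number 12 percentage points lower from compound 3 to compound 4 (beyond the scatter) is within the scatter. Compound 4 is estimated at 50%, with a range from 30% to 70%.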

Compound 4, oral bioavailability: 73%
For compound 4 the middle estimate is 23 percentage points below the measured one, outside the stated range (above it).
By their numbers in this assay, from the lowest: compound 2; then compound 1; then compound 3; then compound 4.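

In this assay, the place on an aromatic carbon ortho to a fluoro group accepts a five-membered aromatic ring with 4 hetero atoms as well as one with 3: 2-methyl-2H-tetrazol-5-yl in place of 3-methyl-1,2,4-oxadiazol-5-yl gives a number 11 percentage points higher from compound 3 to compound 4 (beyond the scatter), and in place of 5-methyl-1,2,4-oxadiazol-3-yl it gives a number 23 percentage points higher from compound 1 to compound 4 (beyond the scatter). The earlier compounds shown here showed only a rearrangement within one ring type, whereas this change alters the ring itself and compound 4 still ends with the highest number of the four, so the gain at this place was not exhausted by the oxadiazole pair. No measurement on these compounds accounts for either step.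

The compounds shown leave open whether this place would also tolerate a tetrazole carrying an ethyl group or a longer chain instead of methyl, or a ring bearing an amine or a carboxylic acid. They also leave open whether the 2-methyl-2H-tetrazol-5-yl group gives a similar number without the fluoro group beside the same large group.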